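The compounds below may be only part of what the source reports. "The series", "measured", "known", "first", "only" and "open" are said of these compounds alone.

Compounds measured so far:
compound 1 `Cc1cn(-c2cc(NC(=O)c3ccc(C)c(Nc4nc(-c5cccnc5)cs4)c3)cc(C(F)(F)F)c2)cn1` — 30 nM
compound 2 `Cc1ccc(C(=O)Nc2cc(-n3ccnc3)cc(C(F)(F)F)c2)cc1Nc1nc(-c2cccnc2)cs1` — 36 nM

In a functional assay on KU812 cells (Homo sapiens) for antiproliferative activity (on this read-out lower numbers stand for stronger inhibition and higher numbers for weaker inhibition), compound 1 stands lowest of the two numbers, with compound 2 nearest: a 1.2-fold higher number from compound 1 to compound 2 (0.08 log units; within the scatter). Compound 3 `Cc1cn(-c2cc(Cl)cc(NC(=O)c3ccc(C)c(Nc4nc(-c5cccnc5)cs4)c3)c2)cn1` differs from compound 1 by chloro in place of trifluoromethyl on an aromatic carbon. Going by the values given here, no measured step touches the trifluoromethyl position; the only step known, a 1.2-fold higher number from compound 1 to compound 2 (0.08 log units; within the scatter), concerns a methyl elsewhere. The estimate therefore rests on compound 1 alone, and a step of a 1.3-fold higher number from compound 1 to compound 3 (0.12 log units; within the scatter) is expected, with a wide range. Compound 3 is estimated at 40 nM, between 15 nM and 110 nM.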

Compound 3, half-maximal inhibitory concentration: 518 nM
The estimate for compound 3 lay 13-fold (1.11 log units) below the measured number; the whole stated range lies below it.
By their numbers in this assay, from the lowest: compounds 1 and 2 (each within the scatter of the next); then compound 3.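

In this assay, exchanging trifluoromethyl for chloro on this aromatic carbon gives a 17-fold higher number from compound 1 to compound 3 (1.24 log units; beyond the scatter) and so places compound 3 beyond the scatter. The earlier step, a 1.2-fold higher number from compound 1 to compound 2 (0.08 log units; within the scatter), showed only that removing a methyl elsewhere left the number within the scatter, whereas this position is clearly sensitive to the group it carries. No measurement at hand accounts for the size of this step.

The compounds shown leave open how a nitrile, a methoxy or a bare hydrogen on this carbon would compare with trifluoromethyl and chloro. They also leave open whether any other group here would match compound 1.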